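Swapping an aryl group for isopropyl on a lactam nitrogen

The source may hold more compounds than are shown below. What is called first, only, known or untested is meant among the compounds shown, and "the series" means these compounds.

Of the compounds shown here, three from one series have been tested in a functional assay on HepG2 cells (Homo sapiens) for antiproliferative activity, read by MTT assay, with a stated time of 72 h; on this read-out higher numbers stand for weaker inhibition and lower numbers for stronger inhibition. Compound 1 `COc1cccc(N2C(=O)COc3ccc(-c4cnc(Cl)c(NS(=O)(=O)c5ccc(F)cc5)c4)cc32)c1` gives only a limit there, > 40000 nM, so no number is known for it; it sits at the limit of > 40000 nM in this assay, at which 1 of the 3 values shown sits. Compound 2 `COc1ccc(N2C(=O)COc3ccc(-c4cnc(OC)c(NS(=O)(=O)c5ccc(F)cc5)c4)cc32)cc1` gives 13100 nM in this assay. Compound 3 `COc1cccc(N2C(=O)COc3ccc(-c4cnc5ccccc5c4)cc32)c1` gives 2080 nM, and the gap between compound 2 and compound 3 lies beyond the usual scatter of repeated measurements, so compound 2 holds the higher of the two numbers and is the weaker of the two.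

The compound still to be measured is compound 4 `COc1ncc(-c2ccc3c(c2)N(C(C)C)C(=O)CO3)cc1NS(=O)(=O)c1ccc(F)cc1`. It differs from compound 2 in one place: isopropyl in place of 4-methoxyphenyl on an amide-type nitrogen in a ring. For the measured compounds named here, no pair among the measured compounds shows what such a swap on the amide-type nitrogen does, so the direction of the step has to be guessed. A modest rise in the number, or none beyond the scatter, is expected; the step from compound 2 to compound 4 is estimated as a 1.2-fold higher number from compound 2 to compound 4 (0.09 log units; within the scatter). Compound 4 is therefore expected to give about 16000 nM in this assay, with a likely range from 4000 nM to 40000 nM.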

Compound 4, half-maximal inhibitory concentration: 37200 nM
Compound 4: middle estimate off by 2.3-fold (0.37 log units), on the low side; low and high end bracket the measured number.
By their numbers in this assay, from the lowest: compound 3; then compound 2; then compound 4. At a limit, above all of these: compound 1.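

In this assay, for the compounds shown here, swapping 4-methoxyphenyl for isopropyl on the amide-type nitrogen in a ring gives a 2.8-fold higher number from compound 2 to compound 4 (0.45 log units; beyond the scatter), the first direct look at what a change in this one place does. The step is modest but beyond the scatter, so this position is not indifferent to the group it carries, and with the rest of the molecule held constant, the 4-methoxyphenyl group goes with stronger inhibition than isopropyl in this pair. The step also moves towards the top of the range this assay reports, where compound 1 gives only a limit and not a number: the limit of > 40000 nM in this assay, at which 1 of the 4 values shown sits.

The swap removes a six-membered aromatic ring and the methoxy oxygen together, so this single pair cannot show which of the two matters, or whether the overall size of the group does; a plain phenyl or a cyclohexyl group on the same nitrogen would begin to separate these. On these data alone, it also remains open whether the step would keep its direction and size with the other groups seen in compound 1 and compound 3, or with a small methyl group on this nitrogen.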